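Working notes: carboxy in place of iodo, cytotoxicity

A few compounds are considered here, and "the series" means these few. Any claim that something is new, unique, unknown or untested is made for them only; others in the source may bear on it.

Measured so far:
- compound 1, `Brc1ccc(Cn2ccc3nc(-c4ccccc4)nc-3c2)cc1`, in an ADME assay on MDBK cells (Bos taurus) for cytotoxicity (a lower number here means that less compound is tolerated, a higher number that more compound is tolerated), gives 83000 nM
- compound 2, `Ic1ccc(Cn2ccc3nc(-c4ccccc4)nc-3c2)cc1`, gives 22000 nM

Compound 2 stands lowest of the two numbers; the nearest is compound 1, with a 3.8-fold lower number from compound 1 to compound 2 (0.58 log units; beyond the scatter). Going by the values given here, that single step, a halogen swapped for a halogen, is the only measured change in the set and is modest.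

Compound 3, `O=C(O)c1ccc(Cn2ccc3nc(-c4ccccc4)nc-3c2)cc1`, is the next member. The change is carboxy in place of iodo on an aromatic carbon. The measured step does not bear on this change: nothing measured shows what happens when a halogen gives way to carboxy, so the direction is open. With compound 2 already at the low end, the estimate for compound 3 is placed back toward the middle of the two measured numbers, with a wide range: 70000 nM, between 20000 nM and 250000 nM, which is expected to mean a 3.2-fold higher number from compound 2 to compound 3 (0.50 log units; beyond the scatter).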

Compound 3, half-maximal cytotoxic concentration: > 100000 nM
Compound 3 gave a limit, no number; the forecaster's own chance of this, stated with the estimate: 30%; middle value at least 1.4-fold (0.15 log units) from the limit.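

The reading for compound 3 in this assay is a limit and not a number: the limit of > 100000 nM in this assay, at which 1 of the 3 values shown sits. Even so, it extends what the halogen pair showed, since a group other than a halogen on this aromatic carbon, para to a large group, gives an at least 4.5-fold higher number from compound 2 to compound 3 (0.65 log units; beyond the scatter), so the low number of compound 2 does not carry over to carboxy. Against bromo the same replacement gives an at least 1.2-fold higher number from compound 1 to compound 3 (0.08 log units; that floor lies within the scatter), so compound 3 cannot be set apart from compound 1, and the clear step holds only against iodo.

As far as these compounds go, how far compound 3 lies past its limit remains open. Also open, from the compounds shown here alone, is whether a primary amide, a methyl ester or an amine on the same aromatic carbon would read like carboxy or like iodo.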